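The compounds below may be only part of what the source reports. "The series", "measured", "known", "first", "only" and "open" are said of these compounds alone.

Measured so far in a functional assay on KB cells (Homo sapiens) for cytotoxicity, read by MTT assay, with a stated time of 72 h; a higher number here means a weaker inhibitor, a lower number a stronger inhibitor:
- Compound 1 `O=S(=O)(c1ccccc1)c1nc2ccccc2nc1N1CCCC1`: 35800 nM
- Compound 2 `Cc1ccc(S(=O)(=O)c2nc3ccccc3nc2N2CCCC2)cc1`: > 50000 nM (a limit of the assay, not a number)
- Compound 3 `O=S(=O)(c1ccccc1)c1nc2ccccc2nc1N1CCCC(O)C1`: 3590 nM

Only compound 1 and compound 3 have exact numbers, and compound 3 has the lower of the two, at 3590 nM. The gap is a 10-fold lower number from compound 1 to compound 3 (1.00 log units; beyond the scatter). That step replaces pyrrolidin-1-yl with 3-hydroxypiperidin-1-yl, so it concerns a different place from the next change.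

Compound 4 `O=S(=O)(c1ccc(F)cc1)c1nc2ccccc2nc1N1CCCC(O)C1` is the next to be measured. It differs from compound 3 by fluoro in place of hydrogen on an aromatic carbon, which is fluoro in place of hydrogen on an aromatic carbon, turning phenyl into 4-fluorophenyl.

The closest measured precedent is also a replacement of hydrogen on an aromatic carbon of that ring, here by methyl: an at least 1.3-fold higher number from compound 1 to compound 2 (0.14 log units; that floor lies within the scatter). It is only a floor, and it was measured with pyrrolidin-1-yl rather than 3-hydroxypiperidin-1-yl in place. Going by the values given here, no fluoro compound has been measured yet, so this precedent is weak.

In this assay, no step beyond the scatter is expected, in either direction. The expected step is a 1.0-fold lower number from compound 3 to compound 4 (0.01 log units; within the scatter). For compound 4 the estimated value is 3500 nM, with an expected range of 1200 nM to 11000 nM.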

Compound 4, half-maximal inhibitory concentration: 18300 nM
Beside the measured number, compound 4's estimate is 5.2-fold (0.72 log units) below it; the measured number lies above the stated range.
By their numbers in this assay, from the lowest: compound 3; then compounds 4 and 1 (each within the scatter of the next). At a limit, above all of these: compound 2.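

In this assay, going by these compounds alone, turning phenyl into 4-fluorophenyl with 3-hydroxypiperidin-1-yl in place gives a 5.1-fold higher number from compound 3 to compound 4 (0.71 log units; beyond the scatter), the first step on this ring that has a size and lies beyond the scatter. A single fluoro on an aromatic carbon, para to a large group, is therefore enough to shift the number at this place, and the shift runs toward a weaker inhibitor, so hydrogen is the better of the two where exact values exist. The earlier methyl change could not show this, since compound 2 gives only a limit and not a number: the limit of > 50000 nM in this assay, at which 1 of the 4 values shown sits.

From the compounds shown here alone, whether the shift belongs to fluoro itself or to any group at this place stays open, and chloro, methoxy or an amine on the same carbon would help to separate the two. Also open, going by these compounds, is whether fluoro brings a similar step with pyrrolidin-1-yl in place of 3-hydroxypiperidin-1-yl, and whether the hydroxyl matters to it, which a plain piperidin-1-yl could help to tell.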